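The source may report more compounds than this note shows. Statements on the series, on what has been measured and on what is new or still open speak of the compounds shown alone.

The series shares one core, seen in compound 1 `CC1CCCN(c2c(C#N)c(C(F)(F)F)nn2-c2ccc(S(C)(=O)=O)cn2)C1`, in which a methyl-bearing saturated nitrogen ring is joined to the core. In a physicochemical assay for solubility (a lower number here means a less soluble compound, a higher number a more soluble compound), compound 1 gives 100 ug/mL. Compound 2 `CS(=O)(=O)c1ccc(-n2nc(C(F)(F)F)c(C#N)c2NC2CCC2)nc1` carries instead a cyclobutylamino group on the same core; for compound 2 this assay records "not determined" (no result reported), so there is no single number on which compound 2 can be placed, and its relation to compound 1 cannot be stated.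

Compound 3 `CC(C)(C)CNc1c(C#N)c(C(F)(F)F)nn1-c1ccc(S(C)(=O)=O)cn1` is the compound that follows from compound 2 by the change (neopentyl in place of cyclobutyl on a nitrogen on an aromatic ring). Going by the values given here, no measured pair in this set shows a step of this kind, so the size of the step from compound 2 to compound 3 in this assay has to be judged from the change alone: a moderate move toward lower solubility is expected, possibly within the scatter of the assay, and compound 1 is the only anchor for the scale. Compound 3 is therefore estimated at 40 ug/mL, expected to fall between 10 ug/mL and 150 ug/mL.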

Compound 3, solubility: < 25 ug/mL
Compound 3: no number, only a limit (the forecaster's own chance of this, stated with the estimate: 10%); middle value at least 1.6-fold (0.20 log units) away from the limit.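

In this assay compound 3 gives < 25 ug/mL, and this is a limit of the assay, not a number: the limit of < 25 ug/mL in this assay, at which 1 of the 3 values shown sits. Going by these compounds alone, compound 3 provides the first reading at this position for an open-chain amino group, and with neopentylamino in place of 3-methylpiperidin-1-yl on an aromatic carbon, the data show an at least 4.0-fold lower number from compound 1 to compound 3 (0.60 log units; beyond the scatter), so this exchange on the shared core is not silent in this read-out. The narrower change from cyclobutylamino to neopentylamino cannot be read, as compound 2 has no single number, and the data therefore do not show what replacing the cyclobutyl ring with the neopentyl chain does on its own.

The compounds shown leave open how far compound 3 lies beyond its limit, and whether the step from the 3-methylpiperidin-1-yl group depends on the ring, on the methyl group or on the hydrogen that neopentylamino keeps on its nitrogen. They also leave open how a morpholine or a chain ending in a carboxylic acid at this position would read in this assay.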